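Propyl to sec-butyl: expected cytotoxicity of compound 4

The source may report more compounds than this note shows. Statements on the series, on what has been measured and on what is new or still open speak of the compounds shown alone.

Compound 1 `CCCSc1nc(Cc2c(F)cccc2Cl)c(C)c(=O)[nH]1` and compound 2 `CCC(C)Sc1nc(Cc2c(F)cccc2Cl)c(C)c(=O)[nH]1` were run in an ADME assay on MT4 cells (Homo sapiens) for activation, read by MTT assay; on this read-out lower numbers stand for higher toxicity in this test and higher numbers for lower toxicity in this test. In this assay compound 1 gives only a limit, > 76000 nM. Compound 2 likewise gives only a limit, > 73000 nM. The change between them, (methyl in place of hydrogen on a saturated chain carbon bound to a saturated chain carbon and a sulfur), therefore yields a step that the two limits leave unreadable from compound 1 to compound 2; this rests on the limit of > 76000 nM in this assay, at which 1 of the 3 values shown sits, and (the limit of > 73000 nM in this assay, at which 1 of the 3 values shown sits).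

Compound 3 `CCCSc1nc(C(C)c2c(F)cccc2Cl)c(CC)c(=O)[nH]1` in this assay also gives only a limit, > 3000 nM, as recorded in the limit of > 3000 nM in this assay, at which 1 of the 3 values shown sits. How the core of compound 3 differs from the core of compound 1 is not broken down here.

Compound 4 `CCc1c(C(C)c2c(F)cccc2Cl)nc(SC(C)CC)[nH]c1=O` is not yet measured. It differs from compound 3 by methyl in place of hydrogen on a saturated chain carbon bound to a saturated chain carbon and a sulfur, the same change as from compound 1 to compound 2, at the same place. Because compound 1 and compound 2 both sit at limits and the step that the two limits leave unreadable from compound 1 to compound 2 is unreadable, no measured size for this change exists. The step from compound 3 to compound 4 is expected to be about a step that the limit leaves unreadable from compound 3 to compound 4. Compound 4 is expected near 20000 nM, estimated between 3000 nM and 100000 nM.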

Compound 4, half-maximal cytotoxic concentration: > 3000 nM
Compound 4: a limit, no number; the forecaster's own chance of this, stated with the estimate: 75%; the middle value does not contradict the limit.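

In this assay compound 4 gives only a limit, > 3000 nM. Compound 3 likewise gives only a limit, > 3000 nM. No step can be read from compound 3 to compound 4, nor from compound 1 to compound 2. The compounds shown leave open whether propyl to sec-butyl shifts the value in this assay at all, on either core.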